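Bromine enters where nothing yet moved the read-out

The source may report more compounds than this note shows. Statements on the series, on what has been measured and on what is new or still open speak of the compounds shown alone.

Compound 2 `C[S+]([O-])c1ccc(N2C(=O)C(C)(C)c3cccnc32)cc1` gives 0% in a functional assay on the whole organism (Pleural cavity) for inhibition, with Rattus norvegicus as the target, at a dose of 25 mg/kg (a higher number here means more inhibition at the dose given (going by the name of the read-out), a lower number less inhibition), level with compound 1 `CC1(C)C(=O)N(c2ccc(S(C)(=O)=O)cc2)c2ncccc21`, which in this assay gives 0%. Within the data shown here, the only step measured so far, no change at the digits printed from compound 1 to compound 2 (within the scatter), is no change. Compound 3 `CC1(C)C(=O)N(c2ccc(Br)cc2)c2ncccc21` differs from compound 2 by one bromine atom in place of a group of 3 heavy atoms (1 carbon, 1 oxygen, 1 sulfur; no ring), on an aromatic carbon. This is a change of another kind than the one measured, so that step bears on it only loosely, and the two values give no ground for a rise. Compound 3 is therefore expected to give 0% in this assay, between -10% and 15%. The expected step is no change at the digits printed from compound 2 to compound 3 (within the scatter).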

Compound 3, a percentage reported as inhibition, in the whole organism at one dose (the size of the read-out at that dose, not a potency): 55%
Compound 3: middle estimate off by 55 percentage points, on the low side; measured number outside the range, above it.
By their numbers in this assay, from the lowest: compounds 1 and 2 (each within the scatter of the next); then compound 3.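

In this assay, the group para to a large group proves able to move the read-out: bromo in place of the sulfur group gives a number 55 percentage points higher from compound 2 to compound 3 (beyond the scatter), and bromo in place of methylsulfonyl gives a number 55 percentage points higher from compound 1 to compound 3 (beyond the scatter). The two sulfur groups had left this position looking silent, yet a single bromine atom on the same aromatic carbon is enough to bring inhibition at this dose. Nothing at hand explains the rise. As far as these compounds go, whether chlorine, a methyl group or an amine at this place would do the same remains open.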